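Adding an octyl group to compound 2

The source may hold more compounds than are shown below. What is called first, only, known or untested is meant among the compounds shown, and "the series" means these compounds.

Measured so far in a functional assay on SW1573 cells (Homo sapiens) for antiproliferative activity, read by sulforhodamine B assay, with a stated time of 48 h; a lower number here means a stronger inhibitor of growth, a higher number a weaker inhibitor of growth:

compound 1 `COC(=O)C#CC(O/C=C/C(=O)OC)C(C)c1ccccc1`: 1200 nM
compound 2 `CCC(C#CC(=O)OC)O/C=C/C(=O)OC`: 540 nM
compound 3 `COC(=O)C#CC(CC(C)C)O/C=C/C(=O)OC`: 380 nM

In this assay, compound 2 cannot be told apart from compound 3, since their numbers lie within the usual scatter. The number for compound 1 is clearly higher. The next compound to be measured is compound 4 `CCCCCCCCCCC(C#CC(=O)OC)O/C=C/C(=O)OC`, which differs from compound 2 by a single change: octyl in place of hydrogen on a saturated chain carbon, three bonds along the chain from an oxygen on an unsaturated carbon and a triple-bonded carbon.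

Two measured steps offer some guidance. The closer one also swaps one alkyl group for a larger one on the chain: a 1.4-fold lower number from compound 2 to compound 3 (0.15 log units; within the scatter). The other removes a phenyl group and is modest: a 2.2-fold lower number from compound 1 to compound 2 (0.35 log units; beyond the scatter). Neither step tests a chain as long as octyl, so the range must stay wide. The closer step points to little change, so no shift beyond the scatter is expected, and the estimate is a 1.4-fold lower number from compound 2 to compound 4 (0.13 log units; within the scatter). In this assay the expected value for compound 4 is 400 nM, with an estimated range from 130 nM to 1200 nM.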

Compound 4, concentration for 50% growth inhibition: 2000 nM
Compound 4: the middle estimate sits 5.0-fold (0.70 log units) below what was measured; measured number above the stated range.
By their numbers in this assay, from the lowest: compounds 3 and 2 (each within the scatter of the next); then compounds 1 and 4 (each within the scatter of the next).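

The saturated chain carbon in compound 2 does not accept every added alkyl group without a cost. Placing octyl there makes the compound a weaker inhibitor of growth in this assay (a 3.7-fold higher number from compound 2 to compound 4 (0.57 log units; beyond the scatter)), the first change at the alkyl part of the chain to go beyond the scatter. The earlier swap of methyl for isopropyl gave no such loss (a 1.4-fold lower number from compound 2 to compound 3 (0.15 log units; within the scatter)), so the result shows that the size of the added alkyl group can matter here, though no measurement shown explains why the octyl compound is weaker.

Two compounds cannot show where between these alkyl groups the loss begins, so a hexyl group would be informative. As far as these compounds go, it also remains open whether an octyl chain carrying an amine or a carboxylic acid would behave the same way.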